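Hydrazone substituent change in a weak HepG2 series

The source may report more compounds than this note shows. Statements on the series, on what has been measured and on what is new or still open speak of the compounds shown alone.

Measured so far:
compound 1 `CCOC(=O)C1=C(N/N=C(/C#N)C(=O)OCC)Nc2[nH]nc(C)c2C1c1ccc(N(C)C)cc1` — 46400 nM
compound 2 `CCOC(=O)C1=C(N/N=C(/C(=O)Br)c2ccc(Br)cc2)Nc2[nH]nc(C)c2C1c1ccc(N(C)C)cc1` — 65000 nM

In a functional assay on HepG2 cells (Homo sapiens) for inhibition, read by MTT assay, with a stated time of 48 h (on this read-out lower numbers stand for stronger inhibition and higher numbers for weaker inhibition), compound 1 gives 46400 nM, and compound 2 gives 65000 nM. Compound 2 has the highest of the two numbers, with compound 1 nearest; a 1.4-fold higher number from compound 1 to compound 2 (0.15 log units; within the scatter), so the two are not separated.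

Compound 3 `CCOC(=O)C1=C(N/N=C(/C(C)=O)C(=O)OCC)Nc2[nH]nc(C)c2C1c1ccc(N(C)C)cc1` differs from compound 2 as follows: a group of 10 heavy atoms (6 carbon, 1 nitrogen, 3 oxygen; no ring) in place of a group of 12 heavy atoms (8 carbon, 1 nitrogen, 1 oxygen, 2 bromine; one six-membered aromatic ring of carbon only), on an amine nitrogen. Going by the values given here, the only measured step bearing on this site is the one from compound 1 to compound 2, which was small: a 1.4-fold higher number from compound 1 to compound 2 (0.15 log units; within the scatter). The group entering in compound 3 has no ring, as in compound 1, rather than the ring-bearing group of compound 2. With a single step at this position and that step within the scatter, no shift beyond the scatter is expected in this assay.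

Compound 3 is therefore estimated at 50000 nM, within 20000 nM to 120000 nM, meaning an expected 1.3-fold lower number from compound 2 to compound 3 (0.11 log units; within the scatter).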

Compound 3, half-maximal inhibitory concentration: > 100000 nM
Compound 3: only a limit was reported (the forecaster's own chance of this, stated with the estimate: 20%); at least 2.0-fold (0.30 log units) between middle value and limit.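

In this assay compound 3 gives > 100000 nM, which is a limit of the assay and not a number. Acetyl in place of cyano on a carbon with a double bond to nitrogen gives the first step in this series to clear the scatter, an at least 2.1-fold higher number from compound 1 to compound 3 (0.33 log units; beyond the scatter), while the earlier step, a 1.4-fold higher number from compound 1 to compound 2 (0.15 log units; within the scatter), did not. Only a floor is available against compound 2, an at least 1.5-fold higher number from compound 2 to compound 3 (0.18 log units; that floor lies within the scatter), and it lies within the scatter, so this result does not separate the ring-bearing group of compound 2 from the group without a ring in compound 3.

Going by these compounds, how far compound 3 lies past its limit stays unknown, and with it the full size of the acetyl step. Also open, on these data alone, is whether an amine, a carboxylic acid or a longer chain on that carbon would give a lower number than cyano or acetyl.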